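The source may report more compounds than this note shows. Statements on the series, on what has been measured and on what is new or still open speak of the compounds shown alone.

Compound 1 `Oc1ccccc1-c1cc(-c2ccccc2F)cc(-c2ccccc2O)n1` and compound 2 `Oc1ccccc1-c1cc(-c2cccc(F)c2)cc(-c2ccccc2O)n1` share a core carrying two 2-hydroxyphenyl groups and one fluorophenyl group. In a functional assay on T47D cells (Homo sapiens) for inhibition (on this read-out lower numbers stand for stronger inhibition and higher numbers for weaker inhibition), compound 1 reaches only the assay limit, > 50000 nM. In this assay compound 2 likewise reaches only the assay limit, > 50000 nM. The step that the two limits leave unreadable from compound 1 to compound 2 cannot be sized, since the limit of > 50000 nM in this assay, at which 2 of the 2 values shown sit, applies to both. Compound 3 `Oc1ccccc1-c1cc(-c2ccc(F)cc2)cc(-c2ccccc2O)n1` differs from compound 2 by 4-fluorophenyl in place of 3-fluorophenyl on an aromatic carbon. Within the data shown here, no measured step reads on this change, so no shift beyond the scatter in this assay is anticipated. Compound 3 is expected near 60000 nM, within 20000 nM to 200000 nM. The expected step is a step that the limit leaves unreadable from compound 2 to compound 3.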

Compound 3, half-maximal inhibitory concentration: > 50000 nM
Compound 3 ended at the assay's limit; the forecaster's own chance of this, stated with the estimate: 85%; the middle value does not contradict the limit.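

No step among compound 1, compound 2 and compound 3 can be read, as all three stand at one assay limit: the limit of > 50000 nM in this assay, at which 3 of the 3 values shown sit.

The compounds shown leave open whether 2-fluorophenyl, 3-fluorophenyl and 4-fluorophenyl differ at all in this assay.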